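Aryl change on the ring nitrogen: from compound 1 toward compound 3

The source may report more compounds than this note shows. Statements on the series, on what has been measured and on what is new or still open speak of the compounds shown alone.

Measured so far:
compound 1 `O=C(CN1CCN(c2ccccc2F)CC1)Nc1nc2ccccc2[nH]1` — 11.6%
compound 2 `O=C(CN1CCN(c2ncccn2)CC1)Nc1nc2ccccc2[nH]1` — 8.77%

In a functional assay, read by spectrophotometry, with a stated time of 30 min, tested at 5 ug/mL (on this read-out higher numbers stand for a stronger effect at the one concentration tested and lower numbers for a weaker effect), compound 1 gives 11.6%, while compound 2 gives 8.77%. Within the data shown here, compound 1 stands at the top of these two numbers only nominally, since the single measured step, a number 2.8 percentage points lower from compound 1 to compound 2 (within the scatter), lies within the scatter and the two cannot be told apart.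

Compound 3 `COc1ccc(N2CCN(CC(=O)Nc3nc4ccccc4[nH]3)CC2)cc1` has not been measured. It differs from compound 1 by 4-methoxyphenyl in place of 2-fluorophenyl on an amine nitrogen in a ring. Among the measured compounds shown here, the only step that bears on this change is the earlier swap at the same ring nitrogen, and that step was within the scatter. For the measured compounds named here, no measured step involves 4-methoxyphenyl, so the expectation rests on that one comparison alone. Compound 3 is therefore expected to show a step of a number 1.6 percentage points lower from compound 1 to compound 3 (within the scatter) in this assay, that is, none beyond the scatter. Compound 3 is estimated at 10%, with a range from 0% to 25%.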

Compound 3, a percentage reported as activity, at one concentration (the size of the read-out at that concentration, not a potency): 7.24%
Beside the measured number, compound 3's estimate is 2.8 percentage points above it; measured number inside the range.
By their numbers in this assay, from the lowest: compounds 3, 2 and 1 (each within the scatter of the next).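

Placing 4-methoxyphenyl on the amine nitrogen in a ring gives a number 4.4 percentage points lower from compound 1 to compound 3 (within the scatter) in this assay, and measured against the pyrimidin-2-yl compound it gives a number 1.5 percentage points lower from compound 2 to compound 3 (within the scatter). The position has now taken three different aromatic groups, including one that adds a hydrogen-bond acceptor to the count, and neither new step separates compound 3 from the other two compounds. No measurement shown bears on why these numbers stay within the scatter of each other.

It remains open whether any group on this nitrogen can move the read-out beyond the scatter, since every compound shown carries a six-membered aromatic ring there, and a benzyl group, an acetyl group or a simple alkyl chain might behave differently. With one concentration tested, these numbers also leave the potency of all three compounds undefined.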